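Ethynyl for thiophen-2-yl in the limit-bound series

The source may hold more compounds than are shown below. What is called first, only, known or untested is meant among the compounds shown, and "the series" means these compounds.

Compound 1 `C#Cc1cn([C@@H]2O[C@H](CO)[C@@H](O)[C@H]2O)c2ncnc(NC)c12`: > 20000 nM (limit)
Compound 2 `Cc1ncnc2c1c(-c1cccs1)cn2[C@@H]1O[C@H](CO)[C@@H](O)[C@H]1O`: > 20000 nM (limit)

In a functional assay on CCRF-CEM cells (Homo sapiens), read by MTT assay, with a stated time of 72 h (on this read-out lower numbers stand for stronger inhibition and higher numbers for weaker inhibition), compound 2 gives > 20000 nM, which is a limit of the assay and not a number. Compound 1 gives > 20000 nM, which is also a limit. The measured picture so far is therefore (the limit of > 20000 nM in this assay, at which 2 of the 2 values shown sit), and neither compound can be placed on a numerical scale.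

The next compound is compound 3 `C#Cc1cn([C@@H]2O[C@H](CO)[C@@H](O)[C@H]2O)c2ncnc(C)c12`. It carries ethynyl in place of thiophen-2-yl on an aromatic carbon, two ring bonds from the ring nitrogen (ethynyl in place of thiophen-2-yl on an aromatic carbon). Within the data shown here, no step between measured compounds is available, so the size of this change in this assay cannot be read from the series. A modest step towards stronger inhibition is expected, and another limit remains quite possible. The estimated step is an at least 2.0-fold lower number from compound 2 to compound 3 (0.30 log units; that floor lies within the scatter). Compound 3 is expected to give about 10000 nM. The expected range for compound 3 runs from 1000 nM to 20000 nM.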

Compound 3, half-maximal inhibitory concentration: 5600 nM
Compound 3: middle estimate off by 1.8-fold (0.25 log units), on the high side; the range from low to high includes it.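

In this assay, ethynyl in place of thiophen-2-yl on the aromatic carbon two ring bonds from the ring nitrogen gives an at least 3.5-fold lower number from compound 2 to compound 3 (0.55 log units; beyond the scatter), which brings the first measured number into the series. With ethynyl kept, methyl in place of methylamino on an aromatic carbon gives an at least 3.5-fold lower number from compound 1 to compound 3 (0.55 log units; beyond the scatter), so a change at either place can move the series off the limit. Both steps are floors and not sizes, and they cannot be ranked against each other, since each starts from a limit: the limit of > 20000 nM in this assay, at which 2 of the 3 values shown sit.

Still open, going by these compounds, is whether the gain at the ethynyl place needs ethynyl itself, or whether a chlorine, a nitrile or a longer chain such as propynyl would give a similar number on the shared core. On these data alone, it is equally open whether a hydrogen, an ethyl or a methoxy in place of methyl would hold the number, and how far each of the two changes counts when the other group is present.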